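The source may hold more compounds than are shown below. What is called first, only, known or untested is meant among the compounds shown, and "the series" means these compounds.

Measured compounds, with their values in a physicochemical assay for lipophilicity, at pH 7.4; on this read-out higher numbers stand for higher lipophilicity and lower numbers for lower lipophilicity:
compound 1 `CNC(=O)c1cc(C(=O)NC2CCC2)cn(Cc2ccccn2)c1=O`, 2.2
compound 2 `CNC(=O)c1cc(C(=O)NC2CCC2)cn(Cc2ccccc2)c1=O`, 3.8
compound 3 `CNC(=O)c1cc(C(=O)NC2CC2)cn(CC2CCOCC2)c1=O`, 1.5

Compound 2 stands highest of the three in this assay, with compound 1 nearest and compound 3 furthest below it. For the measured compounds named here, the only single-point step among the measured compounds is a number 1.60 log units higher from compound 1 to compound 2 (beyond the scatter), phenyl in place of pyridin-2-yl on a saturated chain carbon bound to an aromatic nitrogen. Compound 3 is not linked to compound 2 by a single change.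

Compound 4 `CNC(=O)c1cc(C(=O)NCCC(C)C)cn(Cc2ccccc2)c1=O` differs from compound 2 as isopentyl in place of cyclobutyl on an amide-type nitrogen. Going by the values given here, no measured step alters the group on the amide-type nitrogen, so none bears directly on this change. A modest rise is expected, a number 0.60 log units higher from compound 2 to compound 4 (beyond the scatter). Compound 4 is estimated at 4.4, in the range 3.9 to 4.9.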

Compound 4, distribution coefficient: 4.8
Compound 4: middle estimate off by 0.40 log units, on the low side, within the range that was stated.
By their numbers in this assay, from the lowest: compound 3; then compound 1; then compound 2; then compound 4.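

For the compounds shown here, the group on the amide-type nitrogen is not silent in this assay: isopentyl in place of cyclobutyl gives a number 1.00 log units higher from compound 2 to compound 4 (beyond the scatter), the first reading at this position. Nothing measured accounts for the size of this step.

Isopentyl differs from cyclobutyl in both ring and chain, leaving the two unseparated; cyclopentyl or an n-butyl chain on the same nitrogen would tell them apart. Also open, from the compounds shown here alone, is whether the step carries over to the pyridin-2-yl partner, compound 1.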